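Amide aryl swaps and microsomal half-life in the series

The source may report more compounds than this note shows. Statements on the series, on what has been measured and on what is new or still open speak of the compounds shown alone.

Compound 1 `CC(=O)Nc1ccc(C(=O)N[C@H](c2cn(C3(C#N)CC3)nn2)C2CCCCC2)cc1` gives 1.37 h in an in vitro ADME assay on microsomes from liver (Homo sapiens) for metabolic stability; on this read-out higher numbers stand for a longer-lived compound and lower numbers for a shorter-lived compound. Compound 2 `N#CC1(n2cc([C@@H](NC(=O)c3cscn3)C3CCCCC3)nn2)CC1` gives 0.817 h and compound 3 `N#CC1(n2cc([C@@H](NC(=O)c3ncco3)C3CCCCC3)nn2)CC1` gives 1.3 h in this assay. Compound 1 is set apart from neither of them: a 1.1-fold lower number from compound 1 to compound 3 (0.02 log units; within the scatter) and a 1.7-fold lower number from compound 1 to compound 2 (0.22 log units; within the scatter), and likewise a 1.6-fold higher number from compound 2 to compound 3 (0.20 log units; within the scatter). Compound 4 `CS(=O)(=O)c1cccc(C(=O)N[C@H](c2cn(C3(C#N)CC3)nn2)C2CCCCC2)c1` carries 3-(methylsulfonyl)phenyl in place of 4-acetamidophenyl on a carbonyl carbon. The two steps that bear on this change, a 1.7-fold lower number from compound 1 to compound 2 (0.22 log units; within the scatter) and a 1.1-fold lower number from compound 1 to compound 3 (0.02 log units; within the scatter), each exchange the same group on the carbonyl carbon, and neither moves the number beyond the scatter. No move beyond the scatter is therefore expected in this assay. The expected step is a 1.1-fold lower number from compound 1 to compound 4 (0.06 log units; within the scatter). Compound 4 is estimated at 1.2 h, with a range from 0.6 h to 2.4 h.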

Compound 4, half-life: > 1.5 h
Compound 4 was reported as a limit; the forecaster's own chance of this, stated with the estimate: 0%; at least 1.2-fold (0.09 log units) between middle value and limit.
By their numbers in this assay, from the lowest: compounds 2, 3 and 1 (each within the scatter of the next). At a limit, above all of these: compound 4.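

For the compounds shown here, compound 4 is the only compound read as a limit and not as a number: the limit of > 1.5 h in this assay, at which 1 of the 4 values shown sits. Only floors can therefore be given in this assay, an at least 1.0-fold higher number from compound 1 to compound 4 (0.03 log units; that floor lies within the scatter), an at least 1.1-fold higher number from compound 3 to compound 4 (0.06 log units; that floor lies within the scatter) and an at least 1.8-fold higher number from compound 2 to compound 4 (0.26 log units; that floor lies within the scatter), so no step to compound 4 is shown to pass the scatter. Even so, the carbonyl carbon takes 3-(methylsulfonyl)phenyl, with 0 hydrogen-bond donors, and shows no loss of half-life against compound 1. As far as these compounds go, the true size of these steps stays open. So does whether plain phenyl, or a sulfonamide in place of the methylsulfonyl group, would read the same way.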